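Dihydropyrazole amides: removing the fluoro of compound 3

The compounds below may be only part of what the source reports. "The series", "measured", "known", "first", "only" and "open" are said of these compounds alone.

Measured so far in a functional assay on WM 266-4 cells (Homo sapiens) for inhibition, read by MTT assay, with a stated time of 24 h; a higher number here means a weaker inhibitor of growth, a lower number a stronger inhibitor of growth:
- compound 1, `COc1ccc(C2=NN(C(=O)c3ccc4c(c3)OCCO4)C(c3ccc(F)cc3)C2)cc1`: 3780 nM
- compound 2, `O=C(c1ccc2c(c1)OCCO2)N1N=C(c2ccc(Br)cc2)CC1c1ccccc1`: 1790 nM
- compound 3, `O=C(c1ccc2c(c1)OCCO2)N1N=C(c2ccccc2)CC1c1ccc(F)cc1`: 5210 nM

Compound 3 gives the highest number of the three in this assay. The nearest is compound 1, whose value lies within the scatter of that of compound 3, so no order between the two can be stated. Compound 2 stands furthest away, with a clearly lower number, but it differs from compound 3 in two places, so only the two values themselves can be compared.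

Compound 4, `O=C(c1ccc2c(c1)OCCO2)N1N=C(c2ccccc2)CC1c1ccccc1`, is not yet measured. Its difference from compound 3 is hydrogen in place of fluoro on an aromatic carbon. Among the measured compounds shown here, the only single-point step in the set is a 1.4-fold higher number from compound 1 to compound 3 (0.14 log units; within the scatter), which concerns another ring and another group and did not move the number beyond the scatter. For the measured compounds named here, no measured step removes a fluoro, so the expected size of the step from compound 3 rests on the observation that the one small change seen so far left the number essentially where it was.

The expectation for compound 4 is therefore a step of a 1.1-fold higher number from compound 3 to compound 4 (0.02 log units; within the scatter), i.e. no change beyond the scatter. Compound 4 is estimated at 5500 nM, with a range from 2500 nM to 12000 nM.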

Compound 4, concentration for 50% growth inhibition: 1370 nM
Estimate against measurement, compound 4: 4.0-fold (0.60 log units) above; the measured number lies below the stated range.
By their numbers in this assay, from the lowest: compounds 4 and 2 (each within the scatter of the next); then compounds 1 and 3 (each within the scatter of the next).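

In this assay the change from 4-fluorophenyl to phenyl gives a 3.8-fold lower number from compound 3 to compound 4 (0.58 log units; beyond the scatter), the only step among the compounds shown that lies beyond the scatter: exchanging one fluoro for hydrogen at this place, para to a large group, does move the number. On the other phenyl ring, hydrogen in place of bromo gives a 1.3-fold lower number from compound 2 to compound 4 (0.12 log units; within the scatter), which stays within the scatter, as does a 1.4-fold higher number from compound 1 to compound 3 (0.14 log units; within the scatter) with hydrogen in place of methoxy, and so the only clear single-point shift in this small set sits at the fluoro position. No data at hand explain the shift seen with the loss of fluoro.

The compounds shown hold only fluoro and hydrogen at this place, and it stays open whether a chloro, a methoxy or an amine there would fall with compound 4 or with compound 3. Going by these compounds, the fluoro step is also read on a single background, with no substituent on the other phenyl ring, and its size alongside methoxy or bromo on that ring remains open.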